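From 4-methylphenyl to 2-methylphenyl in compound 3

The source may report more compounds than this note shows. Statements on the series, on what has been measured and on what is new or still open speak of the compounds shown alone.

Values in a functional assay on A549 cells (Homo sapiens) for cytotoxicity, read by sulforhodamine B assay (on this read-out higher numbers stand for weaker inhibition and lower numbers for stronger inhibition), for three compounds
compound 1 `Cc1ccc2c(O)nc(-c3ccccc3C)cc2c1` gives 5890 nM
compound 2 `COc1ccc(-c2cc3cc(C)ccc3c(N3CCN(C)CC3)n2)cc1` gives 7410 nM
compound 3 `Cc1ccc(-c2cc3cc(C)ccc3c(N3CCN(C)CC3)n2)cc1` gives 7240 nM

Compound 3 at 7240 nM lies within the scatter of both compound 2 and compound 1. Compound 4 `Cc1ccc2c(N3CCN(C)CC3)nc(-c3ccccc3C)cc2c1` differs from it by 2-methylphenyl in place of 4-methylphenyl on an aromatic carbon with 2-methylphenyl in place of 4-methylphenyl on an aromatic carbon next to the ring nitrogen. For the measured compounds named here, the one measured step, a 1.0-fold lower number from compound 2 to compound 3 (0.01 log units; within the scatter) with methyl in place of methoxy, is a different change but is small. Compound 1 already carries 2-methylphenyl, lacks the 4-methylpiperazin-1-yl group and gives 5890 nM in the same range. No shift beyond the scatter is therefore expected in this assay here. The expected step is a 1.1-fold lower number from compound 3 to compound 4 (0.03 log units; within the scatter) and no more. Compound 4 is estimated at 6800 nM within an expected range from 3200 nM to 14000 nM.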

Compound 4, half-maximal inhibitory concentration: 7590 nM
Beside the measured number, compound 4's estimate is 1.1-fold (0.05 log units) below it, and the stated range covers the measured number.
By their numbers in this assay, from the lowest: compounds 1, 3, 2 and 4 (each within the scatter of the next).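

In this assay, for the compounds shown here, 2-methylphenyl in place of 4-methylphenyl on the aromatic carbon next to the ring nitrogen gives a 1.0-fold higher number from compound 3 to compound 4 (0.02 log units; within the scatter), the first reading of where the methyl sits on this aryl group. 2-Methylphenyl in place of 4-methoxyphenyl gives a 1.0-fold higher number from compound 2 to compound 4 (0.01 log units; within the scatter), and 4-methylpiperazin-1-yl in place of hydroxy gives a 1.3-fold higher number from compound 1 to compound 4 (0.11 log units; within the scatter), so none of these three swaps separates the compounds on this read-out. Nothing available explains these values. Still open, from the compounds shown here alone, is whether an amine or a carboxylic acid on this aryl group, or a longer chain in place of the methyl on the piperazine, would give a step beyond the scatter.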